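Replacing a side chain on compound 1

A few compounds are considered here, and "the series" means these few. Any claim that something is new, unique, unknown or untested is made for them only; others in the source may bear on it.

Compound 1 `C=CCCCCOc1ccccc1-c1cnc(OCCC=C)n1C`: 9000 nM
Compound 2 `C=CCCCCOc1cc(F)ccc1-c1cnc(OCCC=C)n1C`: 74000 nM

In a functional assay on A549 cells (Homo sapiens) for inhibition, read by colorimetric assay and MTT assay, with a stated time of 72 h (on this read-out higher numbers stand for weaker inhibition and lower numbers for stronger inhibition), compound 1 gives 9000 nM, the lower of the two numbers, so it is the stronger inhibitor of this pair. Compound 3 `C=CCCCCOc1ccccc1-c1cnc(S(=O)(=O)c2ccccc2)n1C` has not yet been measured. Its change from compound 1 is larger than a single-atom swap: phenylsulfonyl in place of (but-3-en-1-yl)oxy on an aromatic carbon. Phenylsulfonyl takes the place of (but-3-en-1-yl)oxy on an aromatic carbon between two ring nitrogen atoms.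

Going by the values given here, only one measured step is available: fluoro in place of hydrogen on an aromatic carbon gave an 8.2-fold higher number from compound 1 to compound 2 (0.91 log units; beyond the scatter). That is a different kind of change, so it guides the size only loosely and says little about direction. Among the compounds with values here, with compound 2 at 74000 nM as the sole comparison, a modest rise in this assay is expected, with wide uncertainty. The estimated step for compound 3 is a 2.2-fold higher number from compound 1 to compound 3 (0.35 log units; beyond the scatter). Compound 3 is expected at 20000 nM, with an estimated range of 5000 nM to 80000 nM.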

Compound 3, half-maximal inhibitory concentration: 38000 nM
The estimate for compound 3 lay 1.9-fold (0.28 log units) below the measured number, and the stated range covers the measured number.
By their numbers in this assay, from the lowest: compound 1; then compounds 3 and 2 (each within the scatter of the next).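

Going by these compounds alone, the position on the aromatic carbon between two ring nitrogen atoms clearly affects this read-out: in this assay, the swap gave a 4.2-fold higher number from compound 1 to compound 3 (0.63 log units; beyond the scatter), the first measured change at this place, as the earlier step involved a fluoro elsewhere in the molecule. Even so, the swap replaces a chain with no ring by a group bearing a six-membered aromatic ring, and compound 3 still gives a numerical value rather than an assay limit. No measurement shown here explains the rise in the number.

With a single replacement at this position, the effect of losing (but-3-en-1-yl)oxy cannot be separated from that of gaining phenylsulfonyl. Going by these compounds, how a methoxy group, an amine or a longer alkenyloxy chain would read at the same place remains open.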